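This account rests on a few compounds, and the source may have more. Where it says the series, first, only, none or still open, it means among the compounds named here.

Measured to date in a functional assay on HT-29 cells (Homo sapiens) for cytotoxicity, read by sulforhodamine B assay; a lower number here means a stronger inhibitor of growth, a higher number a weaker inhibitor of growth:
compound 1 `O=c1oc2ccccc2cc1-c1cn2nc(-c3c([O-])[o+]nn3-c3ccccc3)sc2n1` gives 6.3 ug/mL
compound 2 `O=c1oc2ccc(Cl)cc2cc1-c1cn2nc(-c3c([O-])[o+]nn3-c3ccccc3)sc2n1` gives 7.7 ug/mL
compound 3 `O=c1oc2ccc(Br)cc2cc1-c1cn2nc(-c3c([O-])[o+]nn3-c3ccc(Cl)cc3)sc2n1` gives 5.25 ug/mL

On these numbers compound 3 stands lowest, but its gap to compound 1 and its gap to compound 2 are both within the scatter, so the three compounds sit together in this assay. Among the measured compounds shown here, the single one-point step measured is a 1.2-fold higher number from compound 1 to compound 2 (0.09 log units; within the scatter), a halogen-for-hydrogen exchange on the ring of the shared core, and it shows nothing beyond the scatter.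

Compound 4 `O=c1oc2ccc(Br)cc2cc1-c1cn2nc(-c3c([O-])[o+]nn3-c3ccccc3)sc2n1` differs from compound 3 by hydrogen in place of chloro on an aromatic carbon. For the measured compounds named here, no measured pair covers this exact exchange; the one halogen step in the set sits on the other ring and was flat, and compound 1 and compound 3, which differ at two places including this one, also lie within the scatter of each other. Nothing here argues for a shift beyond the scatter in this assay, so the step is expected to be about a 1.1-fold higher number from compound 3 to compound 4 (0.06 log units; within the scatter). Compound 4 is estimated at 6 ug/mL, in the range 3 ug/mL to 12 ug/mL.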

Compound 4, concentration for 50% growth inhibition: 5.6 ug/mL
Compound 4: the middle estimate sits 1.1-fold (0.03 log units) above what was measured; the measured number falls inside the stated range.
By their numbers in this assay, from the lowest: compounds 3, 4, 1 and 2 (each within the scatter of the next).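

Going from 4-chlorophenyl to phenyl gives a 1.1-fold higher number from compound 3 to compound 4 (0.03 log units; within the scatter), the first direct reading at this position, and it shows no effect beyond the scatter in this assay. Bromo in place of hydrogen and bromo in place of chloro at the other halogen position read the same way, with a 1.1-fold lower number from compound 1 to compound 4 (0.05 log units; within the scatter) and a 1.4-fold lower number from compound 2 to compound 4 (0.14 log units; within the scatter). Chloro in place of hydrogen now reads alike in two settings, with no gap beyond the scatter: the same change on two cores in this assay, a 1.2-fold higher number (0.09 log units; within the scatter) from compound 1 to compound 2 and a 1.1-fold lower number (0.03 log units; within the scatter) from compound 4 to compound 3, 1.3-fold (0.12 log units) apart, within the scatter of two such steps.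

These four compounds carry only hydrogen, chloro or bromo at the two places, leaving open how an amine, a carboxylic acid or a methoxy group on the phenyl ring would read. Also open, from the compounds shown here alone, is whether any change at either place reaches beyond the scatter in this assay.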